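Swapping the Benzyl Arm: Cytotoxicity Outlook for Compound 4

The source may report more compounds than this note shows. Statements on the series, on what has been measured and on what is new or still open speak of the compounds shown alone.

Measured compounds:
- compound 2 `CC1(Nc2ccc(NC(=O)c3cc(Cl)ccc3O)c(Cl)c2)CCCC1` gives 157000 nM
- compound 3 `COc1ccc(CNc2ccc(NC(=O)c3cc(Cl)ccc3O)c(Cl)c2)cc1` gives 80700 nM
- compound 1 `CC(=O)Nc1ccc(NC(=O)c2cc(Cl)ccc2O)c(Cl)c1` gives "not determined" (no result reported)

In an ADME assay on A549 cells (Homo sapiens) for cytotoxicity, read by resazurin assay, with a stated time of 48 h (a higher number here means that more compound is tolerated, a lower number that less compound is tolerated), compound 3 holds the lowest of the two numbers available. Within the data shown here, its only neighbour with a number is compound 2, and the step of a 1.9-fold lower number from compound 2 to compound 3 (0.29 log units; within the scatter) lies within the scatter, so the two compounds cannot be told apart on these data. Compound 1 contributes no number to this assay.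

Compound 4 `O=C(Nc1ccc(NCc2ccc(Br)s2)cc1Cl)c1cc(Cl)ccc1O` keeps the shared core and the nitrogen-bound arm of compound 3, but changes the ring at the end of that arm: 5-bromothiophen-2-yl in place of 4-methoxyphenyl on a saturated chain carbon bound to a nitrogen on an aromatic ring. Among the measured compounds shown here, the one measured step that bears on this position is a 1.9-fold lower number from compound 2 to compound 3 (0.29 log units; within the scatter), where an entirely different group on the same nitrogen left the number within the scatter. For the measured compounds named here, with a single, small step as the only guide, and no measured case of a five-membered ring with a hetero atom at this place, there is no basis to expect a shift beyond the scatter in either direction.

Compound 4 is therefore expected to give about 70000 nM in this assay, with a range from 25000 nM to 200000 nM. The corresponding step of a 1.2-fold lower number from compound 3 to compound 4 (0.06 log units; within the scatter) is estimated to stay small, with the range reflecting the sparse evidence.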

Compound 4, half-maximal cytotoxic concentration: 20700 nM
Estimate against measurement, compound 4: 3.4-fold (0.53 log units) above, outside the stated range (below it).
By their numbers in this assay, from the lowest: compound 4; then compounds 3 and 2 (each within the scatter of the next).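

In this assay, among these compounds, the ring at the end of the arm turns out to matter: with the saturated chain carbon on the nitrogen kept, 5-bromothiophen-2-yl in place of 4-methoxyphenyl gives a 3.9-fold lower number from compound 3 to compound 4 (0.59 log units; beyond the scatter) and is the first change at this position to clear the scatter. Compounds 2 and 3 could not be told apart despite their very different groups on this nitrogen, yet (5-bromothiophen-2-yl)methyl in place of 1-methylcyclopentyl gives a 7.6-fold lower number from compound 2 to compound 4 (0.88 log units; beyond the scatter) and leaves compound 4 with the lowest number of the three, meaning that the least compound is tolerated. The group on this nitrogen can therefore move the number beyond the scatter, although that is seen for this one group only.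

As far as these compounds go, the swap changes several things at once, so it remains open whether the step follows the sulfur-containing ring or the bromine, a question that a plain thiophen-2-yl arm, a 4-bromobenzyl arm or an arm ending in an amine or a carboxylic acid would help to address. No measurement at hand speaks to what lies behind this step.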